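A few compounds are considered here, and "the series" means these few. Any claim that something is new, unique, unknown or untested is made for them only; others in the source may bear on it.

In an ADME assay on K562 cells (Homo sapiens) for cytotoxicity, with a stated time of 72 h (a lower number here means a stronger inhibitor, a higher number a weaker inhibitor), compound 1 `COc1ccc(CNc2ncnc3c2ncn3C2CCCCO2)c(OC)c1` gives > 25000 nM, which is a limit of the assay rather than a number. Compound 2 `COc1cc(OC)c(OC)cc1CNc1ncnc2c1ncn2C1CCCCO1` carries methoxy in place of hydrogen on an aromatic carbon relative to compound 1. Compound 2 gives > 100000 nM, again a limit. The step that the two limits leave unreadable from compound 1 to compound 2 therefore cannot be read. Compound 3 `COc1cccc(CNc2ncnc3c2ncn3C2CCCO2)c1` has a different core; how the core of compound 3 differs from that of compound 1 is not broken down here. Compound 3 gives > 100000 nM, also a limit. The unmeasured compound 4 `COc1cc(CNc2ncnc3c2ncn3C2CCCO2)cc(OC)c1` carries methoxy in place of hydrogen on an aromatic carbon relative to compound 3, the same kind of change as between compound 1 and compound 2, though the place differs: there the methoxy entered ortho to a methoxy group and para to a methoxy group, here meta to a methoxy group. Because compound 3 sits at the limit of > 100000 nM in this assay, at which 2 of the 3 values shown sit, only a small step that the limit leaves unreadable from compound 3 to compound 4 is expected. Compound 4 is therefore estimated at about 150000 nM.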

Compound 4, half-maximal inhibitory concentration: > 100000 nM
Compound 4: a limit, no number; the forecaster's own chance of this, stated with the estimate: 85%; the middle value does not contradict the limit.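

Compound 3 and compound 4 each give only a limit of the assay, not a number, and the step between them cannot be read. The compounds shown leave open which structural change, if any, would give a readable value in this assay.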